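Moving the chlorine on a phenoxy ring of a bicyclic amine

A few compounds are considered here, and "the series" means these few. Any claim that something is new, unique, unknown or untested is made for them only; others in the source may bear on it.

Measured so far in an in vitro assay on SH-SY5Y cells for displacement of a labelled ligand from Neuronal acetylcholine receptor; alpha3/beta4 (Homo sapiens); a higher number here means a weaker inhibitor, a lower number a stronger inhibitor:
- compound 1, `Clc1ccc(C2=CC3CNCC(C2)C3)cn1`, gives 6.2 nM
- compound 2, `C1=C(c2cncnc2)CC2CNCC1C2`, gives 58 nM
- compound 3, `Clc1ccc(Oc2cncc(C3=CC4CNCC(C3)C4)c2)cc1`, gives 40 nM

Among these three numbers compound 3 stands second highest. Its nearest neighbour is compound 2, whose number differs from that of compound 3 by an amount within the usual scatter, so the two cannot be told apart. Compound 1 gives a clearly lower number than compound 3, a gap beyond the scatter, which marks compound 1 as the stronger inhibitor of that pair.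

Compound 4, `Clc1ccccc1Oc1cncc(C2=CC3CNCC(C2)C3)c1`, keeps every atom of compound 3 but joins them differently: 2-chlorophenyl in place of 4-chlorophenyl on an oxygen on an aromatic ring. No pair of measured compounds differs in exactly this way, so nothing shown here tells how large such a step should be. With no such guide, the expectation is for a step from compound 3 to compound 4 that stays within the scatter, in no firm direction, a modest change of no change at the digits printed from compound 3 to compound 4 (within the scatter) at most. Compound 4 is therefore estimated at 40 nM in this assay, with a range from 12 nM to 130 nM.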

Compound 4, inhibition constant: 26 nM
Estimate against measurement, compound 4: 1.5-fold (0.19 log units) above; the measured number falls inside the stated range.
By their numbers in this assay, from the lowest: compound 1; then compounds 4, 3 and 2 (each within the scatter of the next, the first and the last beyond it).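

Moving the chlorine, with 2-chlorophenyl in place of 4-chlorophenyl on an oxygen on an aromatic ring, gives in this assay a 1.5-fold lower number from compound 3 to compound 4 (0.19 log units; within the scatter), a step within the usual scatter. For the compounds shown here, these are the first two compounds here that differ in one place only, and they show that this assay cannot tell the two chlorophenyl groups apart on this oxygen. Nothing measured alongside these numbers offers an explanation for this result.

Still open, from the compounds shown here alone, is whether a plain phenyl with no chlorine, or a 2-methoxyphenyl, on the same oxygen would also give a number within the scatter of these two compounds. Also open, going by these compounds, is whether the same move of the chlorine would give so small a step on a different core.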